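A few compounds are considered here, and "the series" means these few. Any claim that something is new, unique, unknown or untested is made for them only; others in the source may bear on it.

In a functional assay on MCF7 cells (Homo sapiens) for cytotoxicity, read by MTT assay, with a stated time of 96 h (a lower number here means a stronger inhibitor, a higher number a weaker inhibitor), compound 1 `COc1cc(C(=O)c2cn(-c3cccc(C)c3)cc2-c2ccc([N+](=O)[O-])cc2)cc(OC)c1OC` gives 780 nM, the highest of three numbers, against compound 2 `COc1cc(C(=O)c2cn(-c3cccc(C)c3)cc2-c2cccc(N)c2)cc(OC)c1OC` at 130 nM and compound 3 `COc1cc(C(=O)c2cn(-c3cccc(C)c3)cc2-c2ccc(N)cc2)cc(OC)c1OC` at 18 nM. Compound 4 `COc1cc(C(=O)c2cn(-c3ccc(C)cc3)cc2-c2ccc([N+](=O)[O-])cc2)cc(OC)c1OC` differs from compound 1 by 4-methylphenyl in place of 3-methylphenyl on an aromatic nitrogen. Among the compounds with values here, no measured step touches this group. The closest guide is a 7.2-fold lower number from compound 2 to compound 3 (0.86 log units; beyond the scatter), a 4-aminophenyl in place of a 3-aminophenyl, which concerns a different group and gives no direction here. The larger 43-fold lower number from compound 1 to compound 3 (1.64 log units; beyond the scatter) and a 6.0-fold lower number from compound 1 to compound 2 (0.78 log units; beyond the scatter) both remove the nitro group, which compound 4 keeps. No step beyond the scatter is therefore expected in this assay, though a modest one in either direction remains possible. The estimated step is a 1.2-fold lower number from compound 1 to compound 4 (0.08 log units; within the scatter). Compound 4 is estimated at 650 nM, with an expected range of 200 nM to 2000 nM.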

Compound 4, half-maximal inhibitory concentration: 200 nM
Compound 4: middle estimate off by 3.3-fold (0.51 log units), on the high side; low and high end bracket the measured number.
By their numbers in this assay, from the lowest: compound 3; then compounds 2 and 4 (each within the scatter of the next); then compound 1.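

In this assay the swap of 3-methylphenyl for 4-methylphenyl on the aromatic nitrogen gives a 3.9-fold lower number from compound 1 to compound 4 (0.59 log units; beyond the scatter) and so shows that this position responds to where the methyl sits, with the group's heavy atoms unchanged. The earlier compounds shown here varied only the 4-nitrophenyl group and its amino replacements. Nothing measured here accounts for this step.
Still open, as far as these compounds go, is whether the same swap gives a step of this size with the amino groups of compound 2 and compound 3. Also open, from the compounds shown here alone, is how a 4-ethylphenyl or 4-methoxyphenyl group would read on this nitrogen.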